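Pyridinyl for thiophenyl on the shared core

The compounds below may be only part of what the source reports. "The series", "measured", "known", "first", "only" and "open" are said of these compounds alone.

Measured compounds:
- compound 1 `Oc1ccc(-c2cc(-c3ccc(Cl)cc3)nc(-c3cccnc3)c2)cc1`: 22800 nM
- compound 2 `Oc1ccc(-c2cc(-c3cccc(Cl)c3)nc(-c3cccs3)c2)cc1`: 5740 nM

In a functional assay on DU-145 cells (Homo sapiens) for cytotoxicity, read by CCK-8 assay and cell counting, with a stated time of 2 days (a higher number here means a weaker inhibitor, a lower number a stronger inhibitor), compound 2 gives the lower of the two numbers, and compound 1 gives the higher one, beyond the scatter. Compound 3 `Oc1ccc(-c2cc(-c3cccnc3)nc(-c3cccc(Cl)c3)c2)cc1` takes the change (pyridin-3-yl in place of thiophen-2-yl on an aromatic carbon). For the measured compounds named here, no step between measured compounds isolates this change, and the two measured values differ in more than one place. Compound 3 is expected to lose potency moderately, with a 2.1-fold higher number from compound 2 to compound 3 (0.32 log units; beyond the scatter), because compound 1 carrying pyridin-3-yl gives 22800 nM. Compound 3 is estimated at 12000 nM, within 4000 nM to 36000 nM.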

Compound 3, half-maximal inhibitory concentration: 22900 nM
Estimate against measurement, compound 3: 1.9-fold (0.28 log units) below; the range from low to high includes it.
By their numbers in this assay, from the lowest: compound 2; then compounds 1 and 3 (each within the scatter of the next).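

In this assay, for the compounds shown here, pyridin-3-yl in place of thiophen-2-yl gives a 4.0-fold higher number from compound 2 to compound 3 (0.60 log units; beyond the scatter) and so reads this change in one place for the first time. With pyridin-3-yl in place, 3-chlorophenyl in place of 4-chlorophenyl gives a 1.0-fold higher number from compound 1 to compound 3 (0.00 log units; within the scatter) and separates the two chlorophenyl isomers no further. No measurement at hand bears on the reason for the thiophen-2-yl result.

Still open, as far as these compounds go, is whether thiophen-2-yl holds the same lead when paired with 4-chlorophenyl. Also open, from the compounds shown here alone, is how a saturated ring such as piperidine, or an open-chain amine, would read at this position.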